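A Longer Linker and a Methyl Group on a Sulfonamide

The source may report more compounds than this note shows. Statements on the series, on what has been measured and on what is new or still open speak of the compounds shown alone.

Compound 2 `O=S(=O)(NCCNc1nccc(-c2c(-c3cccc(F)c3)nc3sccn23)n1)c1ccc(Br)cc1` is one of three close relatives tested in a functional assay on A-375 cells (Homo sapiens) for cytotoxicity, read by MTT assay; a lower number here means a stronger inhibitor, a higher number a weaker inhibitor. In this assay compound 2 gives 13500 nM; compound 1 `O=S(=O)(NCCCNc1nccc(-c2c(-c3cccc(F)c3)nc3sccn23)n1)c1ccc(F)cc1` gives 14500 nM and compound 3 `Cc1ccc(S(=O)(=O)NCCNc2nccc(-c3c(-c4cccc(F)c4)nc4sccn34)n2)cc1` gives 15400 nM. Compound 2 has the lowest of the three numbers, but the gaps to the others, a 1.1-fold lower number from compound 1 to compound 2 (0.03 log units; within the scatter) and a 1.1-fold higher number from compound 2 to compound 3 (0.06 log units; within the scatter), both fall within the scatter, so the three cannot be ranked.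

Compound 4 `Cc1ccc(S(=O)(=O)NCCCNc2nccc(-c3c(-c4cccc(F)c4)nc4sccn34)n2)cc1` is not yet measured. It differs from compound 2 in one place: (((4-methylphenyl)sulfonyl)amino)methyl in place of ((4-bromophenyl)sulfonyl)amino on a saturated chain carbon, two bonds along the chain from a nitrogen on an aromatic ring. Going by the values given here, two measured steps bear on this. Methyl in place of bromo alone gave a 1.1-fold higher number from compound 2 to compound 3 (0.06 log units; within the scatter). The step of a 1.1-fold lower number from compound 1 to compound 2 (0.03 log units; within the scatter) also combined a change of the aryl group on the sulfonyl with a change of the chain, and it too stayed within the scatter. Both parts of the present change have so far left the number essentially unmoved, and compound 4 is expected to follow suit, with a 1.1-fold higher number from compound 2 to compound 4 (0.05 log units; within the scatter) lying within the scatter. Compound 4 is therefore estimated at 15000 nM, with a likely range from 7500 nM to 30000 nM.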

Compound 4, half-maximal inhibitory concentration: 8380 nM
For compound 4 the middle estimate is 1.8-fold (0.25 log units) above the measured one, within the range that was stated.
By their numbers in this assay, from the lowest: compounds 4, 2, 1 and 3 (each within the scatter of the next).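

Going by these compounds alone, compound 4 allows the chain to be read on its own, which the earlier compounds did not: with the 4-methylphenyl group held fixed, only the chain differs in the step in this assay (a 1.8-fold lower number from compound 3 to compound 4 (0.26 log units; within the scatter)). It also isolates the aromatic group on the longer chain, where methyl stands in place of fluoro (a 1.7-fold lower number from compound 1 to compound 4 (0.24 log units; within the scatter)), while the two changes taken together give a step of similar size (a 1.6-fold lower number from compound 2 to compound 4 (0.21 log units; within the scatter)). All three steps lie within the scatter, so neither the chain length nor the swap of this aromatic group separates these compounds, and no supporting data bear on this result.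

As far as these compounds go, whether a longer chain still would shift the number beyond the scatter remains open. The same holds for an amine or a carboxylic acid on the aromatic ring in place of methyl.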